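From Cyanophenyl to Isobutyl at Bombesin Receptor Subtype-3

The compounds below may be only part of what the source reports. "The series", "measured", "known", "first", "only" and "open" are said of these compounds alone.

Compound 1 `O=C(O)c1ccccc1-c1ccc(CCc2ncc(CC3CCCCC3)[nH]2)cc1`: 7.3 nM
Compound 2 `O=C(O)c1ccccc1-c1ccc(CCc2ncc(CC3CCCC3)[nH]2)cc1`: 7.9 nM
Compound 3 `N#Cc1cccc(Cc2cnc(CCc3ccc(-c4ccccc4C(=O)O)cc3)[nH]2)c1`: 20 nM

All three were measured in an in vitro functional assay on cells for agonist activity at Bombesin receptor subtype-3 (Mus musculus), read by luminescence and calcium flux; a lower number here means that less compound is needed, a higher number that more compound is needed for the effect. Compound 3 stands highest of the three numbers; its nearest neighbour is compound 2, and compound 1 lies furthest, both steps to it beyond the scatter. Compound 4 `CC(C)CCc1cnc(CCc2ccc(-c3ccccc3C(=O)O)cc2)[nH]1` differs from compound 3 by isobutyl in place of 3-cyanophenyl on a saturated chain carbon bound to an aromatic carbon. Within the data shown here, the steps that bear on this are a 2.7-fold higher number from compound 1 to compound 3 (0.44 log units; beyond the scatter) and a 2.5-fold higher number from compound 2 to compound 3 (0.40 log units; beyond the scatter), where a saturated group gave way to the cyanophenyl and the number rose modestly. Going the other way, back to a saturated chain, the author therefore expects a modest lowering for compound 4, about a 2.0-fold lower number from compound 3 to compound 4 (0.30 log units; within the scatter). The estimate for compound 4 is 10 nM, with a range from 4 nM to 30 nM.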

Compound 4, half-maximal effective concentration: 10 nM
Compound 4: middle estimate and measured number agree at the digits printed; low and high end bracket the measured number.
By their numbers in this assay, from the lowest: compounds 1, 2, 4 and 3 (each within the scatter of the next, the first and the last beyond it).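

With isobutyl, which has no ring, a 1.3-fold higher number from compound 2 to compound 4 (0.10 log units; within the scatter) and a 1.4-fold higher number from compound 1 to compound 4 (0.14 log units; within the scatter) both lie within the scatter in this assay, so among these compounds a saturated ring is not needed at this place. Yet a 2.0-fold lower number from compound 3 to compound 4 (0.30 log units; within the scatter) also lies within the scatter, so compound 4 cannot be told apart from compound 3, although compound 1 and compound 2 can. Nothing at hand explains these results. From the compounds shown here alone, whether an amine, an ether or a longer chain at this place would stay in this range remains open.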